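Swapping the ring halogen in a thiazolyl acetamide series

The source may hold more compounds than are shown below. What is called first, only, known or untested is meant among the compounds shown, and "the series" means these compounds.

Measured compounds:
Compound 1 `Cc1csc(NC(=O)Cn2cc(-c3ccccc3Cl)nn2)n1` gives 1240 nM in a functional assay on BMDM cells (Mus musculus, strain C57BL/6) for inhibition, with a stated time of 2 days; on this read-out higher numbers stand for weaker inhibition and lower numbers for stronger inhibition.
Compound 2 `Cc1csc(NC(=O)Cn2cc(-c3ccncc3)nn2)n1` gives 100 nM in this assay.
Compound 3 `Cc1csc(NC(=O)Cn2cc(-c3ccc(Cl)cc3)nn2)n1` gives 520 nM in this assay.

Compound 3 stands second highest of the three numbers: it sits a 2.4-fold lower number from compound 1 to compound 3 (0.38 log units; beyond the scatter) and a 5.2-fold higher number from compound 2 to compound 3 (0.72 log units; beyond the scatter). The unmeasured compound 4 `Cc1csc(NC(=O)Cn2cc(-c3ccc(F)cc3)nn2)n1` differs from compound 3 in one place: fluoro in place of chloro on an aromatic carbon.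

Among the measured compounds shown here, none of the measured steps exchanges one halogen for another. The step of a 2.4-fold lower number from compound 1 to compound 3 (0.38 log units; beyond the scatter) moves the same chloro group to a different position, and the step of a 5.2-fold higher number from compound 2 to compound 3 (0.72 log units; beyond the scatter) replaces a whole ring, so both bear only loosely on the change from chloro to fluoro at the same place. Since fluoro and chloro are both single-atom groups, the expected step of a 1.3-fold higher number from compound 3 to compound 4 (0.10 log units; within the scatter) in this assay is estimated to be small, most likely a slightly higher number. The estimated value for compound 4 is 650 nM, with a range of 250 nM to 1600 nM.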

Compound 4, half-maximal inhibitory concentration: 250 nM
Compound 4: the middle estimate sits 2.6-fold (0.41 log units) above what was measured, within the range that was stated.
By their numbers in this assay, from the lowest: compound 2; then compound 4; then compound 3; then compound 1.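

In this assay, the exchange of one single-atom halogen for another on the carbon-only aromatic ring, para to a large group, is not silent: fluoro in place of chloro gives stronger inhibition (a 2.1-fold lower number from compound 3 to compound 4 (0.32 log units; beyond the scatter)), so this place responds to which halogen it carries, and not only to where a chloro sits or to a whole-ring exchange. Even so, 4-fluorophenyl does not reach pyridin-4-yl (a 2.5-fold higher number from compound 2 to compound 4 (0.40 log units; beyond the scatter)), while its lead over 2-chlorophenyl is wider than that of 4-chlorophenyl (a 5.0-fold lower number from compound 1 to compound 4 (0.70 log units; beyond the scatter)).

Still open, on these data alone, is how this place would respond to groups such as an amine, a carboxylic acid or a methoxy group, and whether the lower number seen with fluoro would hold for any of them. Nothing shown here offers a measured reason for the halogen step.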